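The compounds below may be only part of what the source reports. "The series", "measured", "known", "first", "only" and "open" are said of these compounds alone.

Working notes on the series. Three compounds with the same core and a varied aryl group on an aromatic carbon of a five-membered aromatic ring with 2 nitrogen have been measured. Compound 1 `COc1cc(-c2c(C)nn(-c3nc(-c4ccc(Cl)c(Cl)c4)c(SC(C)C)s3)c2C(=O)O)cc(C(F)(F)F)c1` gives 1380 nM in a functional assay on BJAB cells (Homo sapiens) for antiproliferative activity, with a stated time of 4 days; a higher number here means that more compound is needed for the effect, a lower number that less compound is needed. Compound 2 `Cc1cc(C)cc(-c2c(C)nn(-c3nc(-c4ccc(Cl)c(Cl)c4)c(SC(C)C)s3)c2C(=O)O)c1` gives 2700 nM in this assay. Compound 3 `Cc1cc(C#N)cc(-c2c(C)nn(-c3nc(-c4ccc(Cl)c(Cl)c4)c(SC(C)C)s3)c2C(=O)O)c1` gives 4800 nM in this assay, the highest of the three numbers: a 1.8-fold higher number from compound 2 to compound 3 (0.25 log units; within the scatter), and a 3.5-fold higher number from compound 1 to compound 3 (0.54 log units; beyond the scatter).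

Compound 4 `COc1cccc(-c2c(C)nn(-c3nc(-c4ccc(Cl)c(Cl)c4)c(SC(C)C)s3)c2C(=O)O)c1` is not yet measured. The change is 3-methoxyphenyl in place of 3-cyano-5-methylphenyl on an aromatic carbon. Among the compounds with values here, two measured steps bear on it. The exchange of methyl for cyano gave a 1.8-fold higher number from compound 2 to compound 3 (0.25 log units; within the scatter), and replacing the methoxy and trifluoromethyl pair by cyano and methyl gave a 3.5-fold higher number from compound 1 to compound 3 (0.54 log units; beyond the scatter). Compound 4 keeps a methoxy group, as compound 1 does, and loses the cyano. A move back toward the lower numbers of compound 1 and compound 2 is therefore expected, about a 2.2-fold lower number from compound 3 to compound 4 (0.34 log units; beyond the scatter), though its size may fall within the scatter. Compound 4 is estimated at 2200 nM, with a range of 900 nM to 5500 nM.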

Compound 4, half-maximal effective concentration: 14000 nM
Compound 4: middle estimate off by 6.4-fold (0.80 log units), on the low side; the measured number lies above the stated range.
By their numbers in this assay, from the lowest: compounds 1, 2 and 3 (each within the scatter of the next, the first and the last beyond it); then compound 4.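

In this assay, the 3-methoxyphenyl group of compound 4 stands beyond the scatter from all three aryl groups that carry two substituents: a 2.9-fold higher number from compound 3 to compound 4 (0.46 log units; beyond the scatter), a 5.2-fold higher number from compound 2 to compound 4 (0.71 log units; beyond the scatter) and a 10-fold higher number from compound 1 to compound 4 (1.01 log units; beyond the scatter). The last step is a single change, hydrogen in place of trifluoromethyl, and shows that a retained methoxy group alone does not keep the number near that of compound 1, so the second substituent on this aryl group matters at this position. No available measurement explains the rise.

Going by these compounds, it remains open whether a phenyl group with a single methyl or a single cyano would give a similar number to compound 4. Also open, on these data alone, is whether a chlorine atom or an amine in place of that hydrogen would bring the number back toward that of compound 1.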